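Swapping methyl for chloro: an estimate for compound 3

The source may report more compounds than this note shows. Statements on the series, on what has been measured and on what is new or still open speak of the compounds shown alone.

Compound 1 `O=C(Nc1ccccc1Br)C(Cl)Cl`: 38200 nM
Compound 2 `Cc1cccc(NC(=O)C(Cl)Cl)c1`: "not determined" (no result reported)

Only compound 1 has a number in a functional assay on Bel-7402 cells (Homo sapiens) for antiproliferative activity, read by MTT assay, with a stated time of 72 h; on this read-out lower numbers stand for stronger inhibition and higher numbers for weaker inhibition. Compound 2 has no place on this scale, since its entry reads ("not determined" (no result reported)), so it can be called neither stronger nor weaker than compound 1. This matters for compound 3 `O=C(Nc1cccc(Cl)c1)C(Cl)Cl`, the next compound to be measured. Its closest relative offers no starting value.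

The structural change chloro in place of methyl on an aromatic carbon puts chloro in place of methyl on an aromatic carbon, meta to a group of 6 heavy atoms. Among the compounds with values here, no pair of measured compounds shows what such a swap does here, so the size of the step in this assay cannot be read from the data. No direction is expected, and no step beyond the usual scatter is assumed. Within the data shown here, the only available anchor is compound 1 (38200 nM), and a single anchor calls for a wide range. For compound 3 the expected value is 35000 nM (estimated range 12000 nM to 90000 nM).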

Compound 3, half-maximal inhibitory concentration: 44500 nM
Compound 3: the middle estimate sits 1.3-fold (0.10 log units) below what was measured; the range from low to high includes it.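

Within the data shown here, compound 2 has no number on this scale, so no step from compound 2 to compound 3 can be read, and compound 1 differs from compound 3 in more than one place. No measured evidence bears on this result. As far as these compounds go, what chloro in place of methyl does in this assay remains open for these compounds.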